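The compounds below may be only part of what the source reports. "The series", "measured", "known", "first", "only" and "open" are said of these compounds alone.

Measured so far in an ADME assay on microsomes from liver (Homo sapiens) for metabolic stability, read by LC-MS, using NADPH, with stated times of 5 min and 30 min, tested at 1 uM; a higher number here means faster removal of the compound, a lower number slower removal
- compound 1 `Cn1nccc1-c1cnc(NCc2c(F)ccc3c2CCO3)c2cn[nH]c(=O)c12` gives 14 mL.min-1.g-1
- compound 2 `Cc1nc(CO)ccc1-c1cnc(NCc2c(F)ccc3c2CCO3)c2cn[nH]c(=O)c12` gives 11 mL.min-1.g-1
- compound 3 `CC(=O)N1CCC(c2cnc(NCc3c(F)ccc4c3CCO4)c3cn[nH]c(=O)c23)CC1` gives 207 mL.min-1.g-1

Compound 4 `Cc1ncc(-c2cnc(NCc3c(F)ccc4c3CCO4)c3cn[nH]c(=O)c23)n1C` has not yet been measured. Compound 3 has the highest of the three numbers, and the steps leading to it are large and beyond the scatter, with a 15-fold higher number from compound 1 to compound 3 (1.17 log units; beyond the scatter) and a 19-fold higher number from compound 2 to compound 3 (1.27 log units; beyond the scatter) on record. The remaining step, a 1.3-fold lower number from compound 1 to compound 2 (0.10 log units; within the scatter) lies within the scatter.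

The change now followed puts 1,2-dimethyl-1H-imidazol-5-yl in place of 1-acetylpiperidin-4-yl on an aromatic carbon. The two large steps bear on it most directly when read in reverse, as each of them replaced an aromatic group with 1-acetylpiperidin-4-yl. The entering group is one five-membered aromatic ring, as is the 1-methyl-1H-pyrazol-5-yl of compound 1, so the closest guide is a 15-fold higher number from compound 1 to compound 3 (1.17 log units; beyond the scatter) taken backwards. Among the compounds with values here, the basis is narrow, with three compounds and no measurement yet for any compound carrying 1,2-dimethyl-1H-imidazol-5-yl.

A large fall is therefore expected, estimated as a 12-fold lower number from compound 3 to compound 4 (1.06 log units; beyond the scatter) in this assay and beyond the scatter. For compound 4 the expected value is 18 mL.min-1.g-1 with an estimated range from 8 mL.min-1.g-1 to 45 mL.min-1.g-1 for the measurement.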

Compound 4, intrinsic clearance in microsomes: 10 mL.min-1.g-1
Compound 4: the middle estimate sits 1.8-fold (0.26 log units) above what was measured; the range from low to high includes it.
By their numbers in this assay, from the lowest: compounds 4, 2 and 1 (each within the scatter of the next); then compound 3.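

In this assay, 1,2-dimethyl-1H-imidazol-5-yl in place of 1-acetylpiperidin-4-yl gives a 21-fold lower number from compound 3 to compound 4 (1.32 log units; beyond the scatter), so a third aromatic group on this aromatic carbon now stands far from the one non-aromatic group shown. Against the other aromatic groups, the change gives a 1.1-fold lower number from compound 2 to compound 4 (0.04 log units; within the scatter) and a 1.4-fold lower number from compound 1 to compound 4 (0.15 log units; within the scatter), both within the scatter, so these three compounds cannot be ordered, even though the five-membered aromatic ring now carries two hetero atoms and a second methyl group and the six-membered pyridine of compound 2 differs again. Among the four compounds, all three aromatic groups sit together and only compound 3 stands apart, with none going against this split, but nothing available gives a reason for it.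

Still open, on these data alone, is whether the gap follows the non-aromatic ring itself or the acetyl group on its nitrogen, since compound 3 alone represents both features. A free piperidine amine or a morpholine on this aromatic carbon would help separate the two readings, and a carboxylic acid would test how far the low numbers extend.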